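The source may hold more compounds than are shown below. What is called first, only, known or untested is meant among the compounds shown, and "the series" means these compounds.

Measured compounds:
compound 1 `Cc1ccc(-c2nc(=O)o[nH]2)c(-c2ccc([C@@H](C)N(CC3CC3)c3nc4c(C(=O)O)cccc4o3)cc2)c1` — 2.8 h
compound 2 `CCCCN(c1nc2c(C(=O)O)cccc2o1)[C@H](C)c1ccc(-c2cc(F)ccc2-c2nc(=O)o[nH]2)cc1` — 2.2 h

In an ADME assay on the whole organism (Macaca fascicularis) for metabolic stability, read by LC-MS, using cassette dosing, at a dose of 1 mg/kg by the oral route (on this read-out higher numbers stand for a longer-lived compound and lower numbers for a shorter-lived compound), compound 1 gives 2.8 h, and compound 2 gives 2.2 h. These two numbers sit within the usual scatter of each other, so the data give no real difference between them; compound 2 simply has the smaller of two very similar readings. Going by the values given here, no single-change step between measured compounds is available.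

Compound 3 `C[C@H](c1ccc(-c2cc(F)ccc2-c2nc(=O)o[nH]2)cc1)N(CC1CC1)c1nc2c(C(=O)O)cccc2o1` is the next compound, not yet measured. It is made from compound 2 by one change: cyclopropyl in place of propyl on a saturated chain carbon bound to a nitrogen on an aromatic ring. Compound 1 already carries the cyclopropyl on this same chain carbon, and in this assay it reads close to compound 2, which gives some ground to expect little movement.

The expected step from compound 2 to compound 3 in this assay is therefore a 1.2-fold higher number from compound 2 to compound 3 (0.07 log units; within the scatter), none beyond the scatter. For compound 3 the estimated half-life in this assay is 2.6 h, with a range from 1.3 h to 5.2 h.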

Compound 3, half-life: 4.1 h
For compound 3 the middle estimate is 1.6-fold (0.20 log units) below the measured one, within the range that was stated.
By their numbers in this assay, from the lowest: compounds 2, 1 and 3 (each within the scatter of the next).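

In this assay, going by these compounds alone, going from the propyl to the cyclopropyl gives a 1.9-fold higher number from compound 2 to compound 3 (0.27 log units; within the scatter), the first direct reading of this change, and it shows no difference that stands clear of the scatter. Fluoro in place of methyl on an aromatic carbon gives a 1.5-fold higher number from compound 1 to compound 3 (0.17 log units; within the scatter), so neither of the two places shows a real difference in half-life among these compounds. No measurement at hand explains either reading.

As far as these compounds go, with only these groups to compare, it remains open whether this chain position can shift half-life at all. A longer chain such as hexyl, a chain ending in an amine, or chloro on the aromatic carbon might each give a step beyond the scatter.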